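The source may hold more compounds than are shown below. What is called first, only, known or untested is meant among the compounds shown, and "the series" means these compounds.

Compound 1 `Cc1cc(C)nc(NC[C@@H]2CC3(CC3)CN2C(=O)c2nc(C)sc2-c2ccccc2)n1` is the weakest-looking member of a small set of three amides measured in a functional assay on CHO cells for antagonist activity at Orexin/Hypocretin receptor type 1 (Homo sapiens), read by FLIPR and calcium flux (on this read-out lower numbers stand for lower potency and higher numbers for higher potency (the scale is a negative logarithm)), but only on its face: in this assay compound 1 gives 7.5, the lowest of the three numbers, while compound 2 `Cc1nc(C(=O)N2CCC3(CC3)C[C@H]2CNc2ccc(C(F)(F)F)cn2)c(-c2ccccc2)s1` gives 7.7 and compound 3 `O=C(c1ncccc1-c1ncccn1)N1CC2(CC2)C[C@H]1CNc1ccc(C(F)(F)F)cn1` gives 7.7. Both gaps are within the scatter of the method, so nothing separates compound 1 from the others. Within the data shown here, compounds 2 and 3 differ from compound 1 in more than one place, so no single step between them can be read off; what they do share is the 5-(trifluoromethyl)pyridin-2-yl group on the amine nitrogen, which compound 1 lacks.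

Compound 4 `Cc1nc(C(=O)N2CC3(CC3)C[C@H]2CNc2ccc(C(F)(F)F)cn2)c(-c2ccccc2)s1` now supplies that missing single step. It keeps the core of compound 1 and alters only the amine substituent: 5-(trifluoromethyl)pyridin-2-yl in place of 4,6-dimethylpyrimidin-2-yl on an amine nitrogen. Since compounds 2 and 3 with this same group both sit a little above compound 1, a small upward step is expected in this assay, of the order of a number 0.30 log units higher from compound 1 to compound 4 (within the scatter), a shift that would itself lie within the scatter. Compound 4 is therefore estimated at 7.8, with a range from 7.3 to 8.3.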

Compound 4, negative logarithm of the antagonist equilibrium constant: 8.4
Beside the measured number, compound 4's estimate is 0.60 log units below it, outside the stated range (above it).
By their numbers in this assay, from the lowest: compounds 1, 2 and 3 (each within the scatter of the next); then compound 4.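

In this assay, putting 5-(trifluoromethyl)pyridin-2-yl in place of 4,6-dimethylpyrimidin-2-yl on the amine nitrogen gives a number 0.90 log units higher from compound 1 to compound 4 (beyond the scatter), so the group on this nitrogen is a place where the read-out responds to a change. The earlier compounds shown here could not show this, since their numbers lay within the scatter of one another and they differed from compound 1 in more than one place. The exchange alters the ring and its substituents together, so the step cannot be assigned to any one part of it, and no measurement of any property is at hand to bear on the result.

From the compounds shown here alone, it remains open whether the step belongs to the trifluoromethyl group or to the ring that carries it, a question that a plain pyridin-2-yl, or a pyridin-2-yl carrying a chlorine or a nitrile instead, on this same amine nitrogen would help to settle. Going by these compounds, it is also open whether the same exchange moves the number as far on other amides, such as that of compound 3.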